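Thiophene for Phenyl in an Inactive Nucleoside Series

A few compounds are considered here, and "the series" means these few. Any claim that something is new, unique, unknown or untested is made for them only; others in the source may bear on it.

Compound 1 `COc1nc(N)nc2c1c(-c1ccccc1)cn2[C@@H]1O[C@H](CO)[C@@H](O)[C@H]1O`: > 20000 nM
Compound 2 `COc1nc(N)nc2c1c(-c1cccs1)cn2[C@@H]1O[C@H](CO)[C@@H](O)[C@H]1O`: > 20000 nM
Compound 3 `Nc1nc(N)c2c(-c3ccccc3)cn([C@@H]3O[C@H](CO)[C@@H](O)[C@H]3O)c2n1`: > 20000 nM

In a functional assay on HeLa S3 cells (Homo sapiens) for antiproliferative activity, read by XTT assay, with a stated time of 72 h (a lower number here means a stronger inhibitor, a higher number a weaker inhibitor), compound 1 gives only a limit, > 20000 nM. In this assay compound 2 also gives only a limit, > 20000 nM. Compound 3 likewise gives only a limit, > 20000 nM. The change from compound 1 to compound 2 is thiophen-2-yl in place of phenyl on an aromatic carbon; its step, a step that the two limits leave unreadable from compound 1 to compound 2, cannot be read because of the limit of > 20000 nM in this assay, at which 3 of the 3 values shown sit. The cores of compound 1 and compound 3 differ by amino in place of methoxy on an aromatic carbon, and the step that the two limits leave unreadable from compound 1 to compound 3 is equally unreadable. Compound 4 `Nc1nc(N)c2c(-c3cccs3)cn([C@@H]3O[C@H](CO)[C@@H](O)[C@H]3O)c2n1` carries the same kind of change as compound 2: thiophen-2-yl in place of phenyl on an aromatic carbon; around the place, one description names the 3,4-dihydroxy-5-(hydroxymethyl)oxolan-2-yl group where the other names a group of 9 heavy atoms. Compound 4 is expected to show a step that the limit leaves unreadable from compound 3 to compound 4, an expectation resting on a step that the two limits leave unreadable from compound 1 to compound 2 and on (the limit of > 20000 nM in this assay, at which 3 of the 3 values shown sit). Compound 4 is estimated at 30000 nM, most likely reported again as a limit.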

Compound 4, half-maximal inhibitory concentration: > 20000 nM
Compound 4 gave a limit, no number (the forecaster's own chance of this, stated with the estimate: 90%); the middle value lies beyond the limit too.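

In this assay no step can be read between compound 4 and either compound 3 or compound 2, as all of them give only a limit: the limit of > 20000 nM in this assay, at which 4 of the 4 values shown sit. The compounds shown leave open how strongly any of them inhibits and whether either change alters that.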